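This account rests on a few compounds, and the source may have more. Where it says the series, first, only, none or still open, it means among the compounds named here.

In a functional assay on A-375 cells (Homo sapiens) for antiproliferative activity, read by trypan blue exclusion, with a stated time of 48 h, tested at 10 uM (a lower number here means a stronger effect, a higher number a weaker effect of the compound at the concentration tested), the measured compounds are:

Compound 1, `CCCCCCC#Cc1ccc(S(=O)(=O)Nc2cccc(-c3csc(NC(C)=O)n3)c2)cc1`: 5.8%.
Compound 2, `CCCCCCC#Cc1cccc(S(=O)(=O)Nc2cccc(-c3csc(NC(C)=O)n3)c2)c1`: < 1%, which is a limit of the assay and not a number.
Compound 3, `CCCCCCC#Cc1ccc(S(=O)(=O)Nc2cccc(-c3csc(NC)n3)c2)cc1`: 1.2%.

Among the measured compounds shown here, compound 3 and compound 1 sit within the scatter of each other, as the one measured step shows: a number 4.6 percentage points lower from compound 1 to compound 3 (within the scatter). For the measured compounds named here, the only other value shown is a limit (the limit of < 1% in this assay, at which 1 of the 3 values shown sits), so compound 3 stands among readings that all lie at the bottom of the scale, with no reading set apart from another.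

Compound 4, `CCCCCCC#Cc1ccc(S(=O)(=O)Nc2cccc(-c3csc(Nc4ccccc4)n3)c2)cc1`, has not yet been measured in this assay. It differs from compound 3 in one place: phenyl in place of methyl on a nitrogen on an aromatic ring. The methyl leaves and a phenyl enters, so that methylamino becomes anilino. Going by the values given here, only one measured step touches this nitrogen, a number 4.6 percentage points lower from compound 1 to compound 3 (within the scatter), and it was within the scatter; no measured step exchanges a methyl for a phenyl. With every reading so far near the floor, nothing points to a step beyond the scatter in either direction.

Compound 4 is expected to give about 3%, in a range from 0% to 12%. That amounts to an expected step of a number 1.8 percentage points higher from compound 3 to compound 4 (within the scatter), within the scatter.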

Compound 4, a percentage reported as activity, at one concentration (the size of the read-out at that concentration, not a potency): 5.8%
Estimate against measurement, compound 4: 2.8 percentage points below; the measured number falls inside the stated range.
By their numbers in this assay, from the lowest: compounds 3, 1 and 4 (each within the scatter of the next). At a limit, below all of these: compound 2.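

In this assay, the nitrogen on the aromatic ring has now carried acetyl, methyl and phenyl, and the readings do not separate: a number 4.6 percentage points higher from compound 3 to compound 4 (within the scatter) and no change at the digits printed from compound 1 to compound 4 (within the scatter). The new information is that this place accepts a six-membered aromatic ring of six carbons in place of a single carbon, and in place of acetyl, with the reading staying within the usual scatter, so at this concentration a group of that size does not set compound 4 apart from compound 3 or compound 1. The readings shown give no cause for this result, neither for the phenyl group nor for the other groups at this nitrogen.

As far as these compounds go, each of these readings comes from a single concentration and is not a potency, so it remains open whether compound 1, compound 3 and compound 4 would separate at lower concentrations. From the compounds shown here alone, it also remains open whether this nitrogen would give a similar reading with a longer chain in place of phenyl, or with a carboxylic acid or an amine on the phenyl ring of compound 4.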